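Ethoxy to Morpholinyl on the Carbonyl of Compound 3

The source may report more compounds than this note shows. Statements on the series, on what has been measured and on what is new or still open speak of the compounds shown alone.

Of the compounds shown here, three have been measured in an assay on COS-7 cells for inhibition of patatin-like phospholipase domain-containing protein 2 (Mus musculus); a higher number here means a weaker inhibitor, a lower number a stronger inhibitor. Compound 1 `CCOC(=O)c1ccnc(-c2ccc(OCC)cc2)c1` gives 80000 nM in this assay. Compound 2 `CCOC(=O)c1cccc(-c2ccc(N(C)C)cc2)c1` gives 40000 nM. Going by the values given here, compound 3 `CCOC(=O)Nc1cccc(-c2ccc(N(C)C)cc2)c1` gives 3000 nM, the lowest of the three numbers; its nearest neighbour is compound 2, and the single step that connects two measured compounds in one place, a 13-fold lower number from compound 2 to compound 3 (1.12 log units; beyond the scatter), is well beyond the scatter. Compound 4 `CN(C)c1ccc(-c2cccc(NC(=O)N3CCOCC3)c2)cc1` is built from compound 3 by morpholin-4-yl in place of ethoxy on a carbonyl carbon. Among the compounds with values here, no measured step bears directly on this exchange: the only step available, a 13-fold lower number from compound 2 to compound 3 (1.12 log units; beyond the scatter), concerns the group on the aromatic carbon and leaves the ethoxy untouched, so it gives no guidance on replacing the ethoxy itself. With nothing to point either way, the expected step is a 1.2-fold lower number from compound 3 to compound 4 (0.08 log units; within the scatter), a change that may well stay within the scatter. For compound 4 the estimated value in this assay is 2500 nM, expected to lie between 600 nM and 10000 nM.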

Compound 4, half-maximal inhibitory concentration: > 200000 nM
Compound 4 was reported as a limit (the forecaster's own chance of this, stated with the estimate: 5%); middle value at least 80-fold (1.90 log units) away from the limit.
By their numbers in this assay, from the lowest: compound 3; then compounds 2 and 1 (each within the scatter of the next). At a limit, above all of these: compound 4.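

The group on the carbonyl carbon turns out not to be a neutral place on compound 3 in this assay: the morpholin-4-yl in place of ethoxy gives an at least 66-fold higher number from compound 3 to compound 4 (1.82 log units; beyond the scatter). Going by these compounds alone, until now, the only measured step concerned the group on the aromatic carbon, so this is the first evidence that the ethoxy itself cannot be exchanged freely. The value of compound 4 is a limit, so the step gives only a bound on the size of the change: the limit of > 200000 nM in this assay, at which 1 of the 4 values shown sits.

The compounds shown do not separate the ring from the linking nitrogen, since morpholin-4-yl brings both in at once. From the compounds shown here alone, whether an open-chain dimethylamino, a piperidin-1-yl ring or a shorter methoxy on the same carbonyl carbon would keep the number of compound 3 remains open.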